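The source may report more compounds than this note shows. Statements on the series, on what has been measured and on what is new or still open speak of the compounds shown alone.

Within the data shown here, compound 2 `CC/C(=C(/c1ccc(/C=C/C(=O)O)cc1)c1ccc2[nH]ncc2c1F)c1ccccc1` has the lowest number of the two measured so far in a functional assay on MCF7 cells (Homo sapiens) for cytotoxicity, read by CellTiter-Glo, with a stated time of 5 days (on this read-out higher numbers stand for weaker inhibition and lower numbers for stronger inhibition), where compound 2 gives 3 nM. Among the measured compounds shown here, the only other measured compound is compound 1 `CC/C(=C(/c1ccc(/C=C/C(=O)O)cc1)c1cc2cn[nH]c2cc1C)c1ccccc1`, which in this assay gives 468 nM, a gap captured by the step of a 160-fold lower number from compound 1 to compound 2 (2.19 log units; beyond the scatter). Compound 3 `CC/C(=C(/c1ccc(/C=C/C(=O)O)cc1)c1ccc2[nH]nc(Cl)c2c1)c1ccccc1` has not yet been measured. It differs from compound 2 in one place: 3-chloro-1H-indazol-5-yl in place of 4-fluoro-1H-indazol-5-yl on a double-bonded chain carbon bound to an aromatic carbon and a double-bonded chain carbon. For the measured compounds named here, only that one measured step bears on this change, and it exchanged one decorated form of the same ring system for another, just as the present change does. It shows that the choice of group on this ring system can move the number greatly, so a step of some size is expected for compound 3, most likely toward a higher number, with the expected step being a 5.0-fold higher number from compound 2 to compound 3 (0.70 log units; beyond the scatter). Compound 3 is therefore estimated at 15 nM, within a range from 3 nM to 100 nM.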

Compound 3, half-maximal inhibitory concentration: 284 nM
Estimate against measurement, compound 3: 19-fold (1.28 log units) below, and the stated range ends below it.
By their numbers in this assay, from the lowest: compound 2; then compounds 3 and 1 (each within the scatter of the next).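

In this assay, 3-chloro-1H-indazol-5-yl in place of 4-fluoro-1H-indazol-5-yl gives a 95-fold higher number from compound 2 to compound 3 (1.98 log units; beyond the scatter) even though the two groups have the same counts of heavy atoms, hydrogen-bond donors and acceptors, so these counts alone do not tell how a group at this position will behave. The 3-chloro-1H-indazol-5-yl and 6-methyl-1H-indazol-5-yl groups give a 1.6-fold lower number from compound 1 to compound 3 (0.22 log units; within the scatter) and so cannot be told apart, which leaves compound 2, with its 4-fluoro-1H-indazol-5-yl group, alone at the low end among these three. No measurement here explains the large step.

The two groups in this step differ in both the halogen and where it sits on the indazole, and the effects of these two differences remain unseparated. A 4-chloro-1H-indazol-5-yl or 3-fluoro-1H-indazol-5-yl group would pull them apart, while the plain 1H-indazol-5-yl group would show what the fluorine adds.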